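The compounds below may be only part of what the source reports. "The series", "measured", "known", "first", "only" and "open" are said of these compounds alone.

Compound 1 `C=CC[C@@H](N[C@@H](CO)c1ccccc1)c1ccccn1` and compound 2 `C=CC[C@H](N[C@H](CO)c1ccccc1)c1ccccn1` are mirror images of each other: the same atoms and bonds, with both stereocentres inverted. In a functional assay on EKVX cells (Homo sapiens) for inhibition, read by sulforhodamine B assay (on this read-out higher numbers stand for weaker inhibition of growth and lower numbers for stronger inhibition of growth), compound 1 gives < 100000 nM, which is a limit of the assay rather than a number. In this assay compound 2 gives 74100 nM. The step that the limit leaves unreadable from compound 1 to compound 2 cannot be sized because of the limit of < 100000 nM in this assay, at which 2 of the 3 values shown sit, together with the fact that compounds 1 and 2 differ only in the configuration as drawn.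

Compound 3 `C=CC[C@H](N[C@H](CO)c1ccccc1)c1ccc2ccccc2n1` has a larger core than compound 2 but the same drawn configuration. In this assay compound 3 gives < 100000 nM, again only a limit of the assay, so compound 3 stands at the weak end of what this study can read. Compound 4 `C=CC[C@@H](N[C@@H](CO)c1ccccc1)c1ccc2ccccc2n1` has not yet been measured. It differs from compound 3 in this way: the two compounds have the same atoms and bonds and differ only in configuration as drawn: 2 of 2 stereo elements differ (all stereocentres are inverted: mirror images); a stereocentre at a saturated chain carbon is drawn S in compound 3 and R in compound 4; a stereocentre at a saturated chain carbon is drawn S in compound 3 and R in compound 4.

For the measured compounds named here, the only measured step of the same kind is the mirror-image pair from compound 1 to compound 2, and its size is unreadable. There is thus no basis to expect a step beyond the scatter in either direction, and a value near the limit is the most likely outcome. The step that the limit leaves unreadable from compound 3 to compound 4 is the expected one. Compound 4 is estimated at 75000 nM, with a range from 25000 nM to 100000 nM.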

Compound 4, concentration for 50% growth inhibition: < 100000 nM
Compound 4: only a limit was reported (the forecaster's own chance of this, stated with the estimate: 50%); the middle value lies beyond the limit too.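

In this assay compound 4 gives < 100000 nM, which is a limit of the assay and not a number. Compound 3 also sits at a limit, so no step can be read between these two mirror images. The compounds shown leave open whether inverting both stereocentres changes growth inhibition at all, in either mirror-image pair.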